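Ring-nitrogen demethylation in a small oxazolidinone series

The compounds below may be only part of what the source reports. "The series", "measured", "known", "first", "only" and "open" are said of these compounds alone.

Measured compounds:
compound 1, `CN(C)C[C@H]1CN(C)C(=O)O1`, 2200 nM
compound 2, `CN1C[C@@H](C[N+](C)(C)C)OC1=O`, 3610 nM
compound 3, `CN(C)C[C@H]1CNC(=O)O1`, 450 nM

These three compounds were compared in an assay on Hippocampus for displacement of a labelled ligand from Neuronal acetylcholine receptor; alpha4/beta2 (Rattus norvegicus); a higher number here means a weaker inhibitor, a lower number a stronger inhibitor. Compound 1 gives 2200 nM, and its counterpart compound 3 gives 450 nM. The change between them, (hydrogen in place of methyl on an amide-type nitrogen in a ring), made a step of a 4.9-fold lower number from compound 1 to compound 3 (0.69 log units; beyond the scatter). Compound 2 gives 3610 nM; how its core differs from that of compound 1 is not broken down here, and the values of compound 2 and compound 1 lie within the scatter of each other.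

Compound 4, `C[N+](C)(C)C[C@@H]1CNC(=O)O1`, has not yet been measured in this assay. It is related to compound 2 by hydrogen in place of methyl on an amide-type nitrogen in a ring. This is the same kind of change as that from compound 1 to compound 3, though here the place is on a ring atom that bears a group of 5 heavy atoms rather than 4. Within the data shown here, on the strength of the one earlier step, compound 4 is expected to show a step of about a 4.9-fold lower number from compound 2 to compound 4 (0.69 log units; beyond the scatter) in this assay, because compound 3 reached 450 nM from compound 1. For compound 4 an estimate of 740 nM is therefore made, in a range from 330 nM to 1700 nM.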

Compound 4, inhibition constant: 429 nM
For compound 4 the middle estimate is 1.7-fold (0.24 log units) above the measured one; low and high end bracket the measured number.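

In this assay, hydrogen in place of methyl on the amide-type nitrogen in the ring gave an 8.4-fold lower number from compound 2 to compound 4 (0.93 log units; beyond the scatter), so the second core responded in the same direction as the first. Set beside the earlier step, the size of the change shows no difference that can be told apart between the two cores: the same change on two cores in this assay, a 4.9-fold lower number (0.69 log units; beyond the scatter) from compound 1 to compound 3 and an 8.4-fold lower number (0.93 log units; beyond the scatter) from compound 2 to compound 4, 1.7-fold (0.24 log units) apart, within the scatter of two such steps. This supports carrying the change between these two cores only; two pairs do not show that it would hold on any other core, and they do not explain why the hydrogen compounds give the lower numbers.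

The compounds shown carry only methyl or hydrogen on that ring nitrogen, so it remains open how an ethyl group, a longer chain or an acetyl group there would read in this assay. As far as these compounds go, it is also open whether the step would persist with a primary amine or a secondary amine at the end of the side chain.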